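Diacylhydrazine series: moving the halogen on the hydrazide benzoyl

A few compounds are considered here, and "the series" means these few. Any claim that something is new, unique, unknown or untested is made for them only; others in the source may bear on it.

Compound 2 `CC(C)(C)N(NC(=O)c1ccccc1Br)C(=O)c1ccccc1Cl` gives 316 nM in an assay on cells for agonist activity at ecdysone receptor (Bombyx mori), read by a luciferase reporter, with a stated time of 24 h (a higher number here means that more compound is needed for the effect, a lower number that less compound is needed), and stands highest of the two numbers measured. Within the data shown here, compound 1 `CC(C)(C)N(NC(=O)c1ccccc1)C(=O)c1ccc(Cl)cc1Cl` gives 117 nM in this assay, a gap beyond the scatter; no single-point step between these two is defined. Compound 3 `CC(C)(C)N(NC(=O)c1cccc(Cl)c1)C(=O)c1ccccc1Cl` differs from compound 2 by 3-chlorophenyl in place of 2-bromophenyl on a carbonyl carbon. A modest step toward a lower number is expected, since compound 1 with 117 nM shows lower values are reachable here. For compound 3 the estimate is 90 nM, range 30 nM to 300 nM, a step of a 3.5-fold lower number from compound 2 to compound 3 (0.55 log units; beyond the scatter).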

Compound 3, half-maximal effective concentration: 155 nM
Beside the measured number, compound 3's estimate is 1.7-fold (0.24 log units) below it; measured number inside the range.
By their numbers in this assay, from the lowest: compounds 1 and 3 (each within the scatter of the next); then compound 2.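

On the carbonyl carbon whose other neighbour is the amide-type nitrogen, 3-chlorophenyl in place of 2-bromophenyl gives the series its first one-place comparison: in this assay the change reads a 2.0-fold lower number from compound 2 to compound 3 (0.31 log units; beyond the scatter) and is modest. The halogen and its place on the ring change together, so neither can be credited alone. No measured evidence bears on the cause of this step.

Which of the two changes carries the step stays open. So does the outcome with a methoxy group or an amine on this phenyl ring.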